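Working notes: from methyl to isobutyl on compound 1

A few compounds are considered here, and "the series" means these few. Any claim that something is new, unique, unknown or untested is made for them only; others in the source may bear on it.

Measured in a functional assay on MCF7 cells (Homo sapiens) for cytotoxicity, read by MTT assay; a higher number here means a weaker inhibitor, a lower number a stronger inhibitor:
- compound 1 `C[C@H](NC(=S)Nc1cc(C(F)(F)F)cc(C(F)(F)F)c1)c1nc2ccccc2[nH]1`: 187000 nM
- compound 2 `C[C@@H](NC(=S)NCc1ccccc1)c1nc2ccccc2[nH]1`: 14300 nM

Compound 1 holds the higher of the two numbers at 187000 nM, and compound 2 holds the lower at 14300 nM, a gap beyond the usual scatter. Among the measured compounds shown here, no pair of measured compounds differs in one place only, so the series gives no direct measure of any single change.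

Compound 3 `CC(C)C[C@H](NC(=S)Nc1cc(C(F)(F)F)cc(C(F)(F)F)c1)c1nc2ccccc2[nH]1`, not yet measured in this assay, differs from compound 1 by isopropyl in place of hydrogen on a saturated chain carbon, two bonds along the chain from an amide-type nitrogen and an aromatic carbon. Cut one bond further out, the same difference reads methyl to isobutyl.

The expectation rests on thin ground. Compound 1 stands high at 187000 nM, and compound 2 at 14300 nM shows that much lower numbers occur in this series, so a moderate move downward is expected rather than a further rise. The expected change is a 2.7-fold lower number from compound 1 to compound 3 (0.43 log units; beyond the scatter), and its size is uncertain. Compound 3 is estimated at 70000 nM, with an expected range of 20000 nM to 200000 nM.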

Compound 3, half-maximal inhibitory concentration: 16300 nM
Beside the measured number, compound 3's estimate is 4.3-fold (0.63 log units) above it; the measured number lies below the stated range.
By their numbers in this assay, from the lowest: compounds 2 and 3 (each within the scatter of the next); then compound 1.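

In this assay, among the compounds shown here, the saturated chain carbon two bonds along the chain from an amide-type nitrogen and an aromatic carbon is a position where the substituent matters: isopropyl in place of hydrogen gives an 11-fold lower number from compound 1 to compound 3 (1.06 log units; beyond the scatter), the first single-place change that the series can read. On the core of compound 1, the same difference, read as methyl to isobutyl, therefore moves the number down, and the larger group brings no loss in this read-out. This remains an observation on one pair, and no measurement at hand accounts for the step.

As far as these compounds go, what remains open is how the step depends on the group at this carbon: an ethyl group, a straight butyl chain, a cyclohexyl ring or an aminomethyl group there would show whether the isobutyl result reflects a trend or is specific to that group. From the compounds shown here alone, it is also open whether the same change gives a comparable step on compound 2, where the rest of the molecule differs from that of compound 1.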